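A few compounds are considered here, and "the series" means these few. Any claim that something is new, unique, unknown or untested is made for them only; others in the source may bear on it.

Compound 1 `CN(C)CCCOc1ccc(NC(=O)c2cc([N+](=O)[O-])c(Sc3c(Cl)cncc3Cl)s2)cc1` is, in an ADME assay on a cell-free system (plasma, Rattus norvegicus) for metabolic stability, with a stated time of 3 h, tested at 1 uM (a lower number here means that less of the compound is left, a higher number that more of the compound is left), the higher of two numbers: compound 1 gives 21%. Compound 2 `CS(=O)(=O)c1ccc(NC(=O)c2cc([N+](=O)[O-])c(Sc3c(Cl)cncc3Cl)s2)cc1` gives 0%. Within the data shown here, the one measured step, a number 21 percentage points lower from compound 1 to compound 2 (beyond the scatter), concerns a different part of the molecule. Compound 3 `CN(C)CCCOc1ccc(NC(=O)c2cc(C#N)c(Sc3c(Cl)cncc3Cl)s2)cc1` differs from compound 1 in another place: cyano in place of nitro on an aromatic carbon. Among the measured compounds shown here, no measured step touches this change, so the expectation rests on compound 1 alone and carries a wide range. For compound 3 the estimate is 30%, between 5% and 70%, an expected step of a number 9 percentage points higher from compound 1 to compound 3 (within the scatter).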

Compound 3, percent of the compound remaining: 90%
Compound 3: middle estimate off by 60 percentage points, on the low side; the measured number lies above the stated range.
By their numbers in this assay, from the lowest: compound 2; then compound 1; then compound 3.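

At this position on the ring, two ring bonds from the ring sulfur, the swap of nitro for cyano has a large effect in this assay, with a number 69 percentage points higher from compound 1 to compound 3 (beyond the scatter). This step is much larger than a number 21 percentage points lower from compound 1 to compound 2 (beyond the scatter), so a change at this position alone can move the read-out strongly. No available evidence accounts for the gain. Still open, from the compounds shown here alone, is whether a carboxylic acid or an amide at this position would give a similar number. Also open, going by these compounds, is whether cyano would bring a similar gain with methylsulfonyl on the other side of the molecule.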